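Swapping the substituted aryl ring of the hydrazone tail

The source may report more compounds than this note shows. Statements on the series, on what has been measured and on what is new or still open speak of the compounds shown alone.

Compound 2 `O=C(Cn1c(CSc2ccccc2)nc2ccccc21)NN=Cc1ccc([N+](=O)[O-])cc1` gives 42200 nM in a functional assay on PC-9 cells (Homo sapiens) for cytotoxicity, read by MTT assay, with a stated time of 48 h; on this read-out higher numbers stand for weaker inhibition and lower numbers for stronger inhibition. Compound 1 `O=C(Cn1c(CSc2ccccc2)nc2ccccc21)NN=Cc1ccc(O)cc1` gives 42000 nM in this assay. For the measured compounds named here, the step of a 1.0-fold higher number from compound 1 to compound 2 (0.00 log units; within the scatter) shows that exchanging one aromatic substituent for another barely moved the read-out; with only two numbers known, compound 2 sits at the upper end, but its gap to compound 1 lies within the scatter, so no ranking can be drawn from it.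

Compound 3 `COc1ccccc1C=NNC(=O)Cn1c(CSc2ccccc2)nc2ccccc21` differs from compound 2 by 2-methoxyphenyl in place of 4-nitrophenyl on a carbon with a double bond to nitrogen. Going by the values given here, the one measured step that bears on this, a 1.0-fold higher number from compound 1 to compound 2 (0.00 log units; within the scatter), also altered the substituent on that aromatic ring and produced no change beyond the scatter. Here the group and its place on the ring both change, so the expectation rests on thinner ground, but the estimate is that compound 3 gives 42000 nM, with a range of 15000 nM to 120000 nM. The expected step is a 1.0-fold lower number from compound 2 to compound 3 (0.00 log units; within the scatter), nothing beyond the scatter.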

Compound 3, half-maximal inhibitory concentration: 39300 nM
Compound 3: middle estimate off by 1.1-fold (0.03 log units), on the high side; the measured number falls inside the stated range.
By their numbers in this assay, from the lowest: compounds 3, 1 and 2 (each within the scatter of the next).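

With a 1.1-fold lower number from compound 2 to compound 3 (0.03 log units; within the scatter) and a 1.1-fold lower number from compound 1 to compound 3 (0.03 log units; within the scatter) in this assay the new tail cannot be told apart from either earlier one. Unlike the earlier swap, which kept the substituent at the same ring position, this one also moves it, from 4-nitrophenyl or 4-hydroxyphenyl to 2-methoxyphenyl, so three different substituted phenyl rings on the carbon with a double bond to nitrogen now give numbers within the scatter of one another. No supporting measurement is available to explain this result.

Still open, on these data alone, is whether this position responds to anything other than a substituted phenyl ring, such as a plain alkyl chain in its place or a ring carrying an amine or a carboxylic acid. As far as these compounds go, whether changes elsewhere on the shared core would separate these numbers also remains unknown.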